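The source may hold more compounds than are shown below. What is called first, only, known or untested is meant among the compounds shown, and "the series" means these compounds.

Values measured so far in a functional assay on HCT-116 cells (Homo sapiens) for cytotoxicity, read by MTT assay, with a stated time of 48 h; a lower number here means a stronger inhibitor of growth, a higher number a weaker inhibitor of growth:
- compound 1 `Cn1c(C(F)(F)F)nc2cc(Cl)c(Cl)cc21` gives 56000 nM
- compound 2 `FC(F)(F)c1cccc(Cn2c(C(F)(F)F)nc3cc(Cl)c(Cl)cc32)c1` gives 50500 nM
- compound 3 `O=[N+]([O-])c1cccc(Cn2c(C(F)(F)F)nc3cc(Cl)c(Cl)cc32)c1` gives 22800 nM

Compound 3 holds the lowest of the three numbers, with compound 2 nearest to it. The unmeasured compound 4 `Nc1cccc(Cn2c(C(F)(F)F)nc3cc(Cl)c(Cl)cc32)c1` has amino in place of nitro on an aromatic carbon. Among the measured compounds shown here, one measured step bears on that carbon, trifluoromethyl to nitro (a 2.2-fold lower number from compound 2 to compound 3 (0.35 log units; beyond the scatter)), and it is modest. For the measured compounds named here, no measured compound carries amino, so direction is poorly defined. In this assay a step no larger than that one is expected, more likely towards a higher number. The estimated step is a 1.3-fold higher number from compound 3 to compound 4 (0.12 log units; within the scatter) and may not exceed the scatter. Compound 4 is estimated at 30000 nM (expected range 12000 nM to 70000 nM).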

Compound 4, concentration for 50% growth inhibition: 22600 nM
Beside the measured number, compound 4's estimate is 1.3-fold (0.12 log units) above it; the range from low to high includes it.
By their numbers in this assay, from the lowest: compounds 4 and 3 (each within the scatter of the next); then compounds 2 and 1 (each within the scatter of the next).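

In this assay the step of a 1.0-fold lower number from compound 3 to compound 4 (0.00 log units; within the scatter) shows that amino and nitro on this aromatic carbon cannot be told apart, although amino brings a hydrogen-bond donor that nitro lacks. Amino also holds the gain over trifluoromethyl, with a 2.2-fold lower number from compound 2 to compound 4 (0.35 log units; beyond the scatter) and, for 3-aminophenyl in place of hydrogen on the saturated chain carbon, a 2.5-fold lower number from compound 1 to compound 4 (0.39 log units; beyond the scatter) as well. No evidence on hand accounts for these results.

From the compounds shown here alone, whether an acetamide, a carboxylic acid or a hydroxyl on this carbon would separate from amino and nitro remains open.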